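A few compounds are considered here, and "the series" means these few. Any claim that something is new, unique, unknown or untested is made for them only; others in the source may bear on it.

Among the compounds with values here, in a functional assay on KB cells (Homo sapiens) for cytotoxicity, read by MTT assay, with a stated time of 3 days (a higher number here means a weaker inhibitor, a lower number a stronger inhibitor), compound 1 (`N#Cc1c(Cl)nc(SCc2nc3ccccc3[nH]2)nc1-c1ccccc1`) gives 3.7 nM and compound 2 (`N#Cc1c(Nc2ccccc2)nc(SCc2nc3ccccc3[nH]2)nc1-c1ccccc1`) gives 2.9 nM, so compound 2 stands within the scatter of compound 1, the only other measured compound. Compound 3 (`CNc1nc(SCc2nc3ccccc3[nH]2)nc(-c2ccccc2)c1C#N`) keeps the core of compound 2 and changes one group: methyl in place of phenyl on a nitrogen on an aromatic ring. This is methyl in place of phenyl on a nitrogen on an aromatic ring, or anilino to methylamino. Within the data shown here, no measured compound yet carries methylamino, so the basis is thin. Even so, no step beyond the scatter is expected in this assay, given a 1.3-fold lower number from compound 1 to compound 2 (0.11 log units; within the scatter), the one measured step, with anilino in place of chloro on an aromatic carbon. The estimated step is a 1.4-fold higher number from compound 2 to compound 3 (0.14 log units; within the scatter). The expected value for compound 3 is 4 nM, with an estimated range from 1.3 nM to 13 nM.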

Compound 3, half-maximal inhibitory concentration: 2.7 nM
For compound 3 the middle estimate is 1.5-fold (0.17 log units) above the measured one, and the stated range covers the measured number.
By their numbers in this assay, from the lowest: compounds 3, 2 and 1 (each within the scatter of the next).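

With a 1.1-fold lower number from compound 2 to compound 3 (0.03 log units; within the scatter) in this assay the phenyl on this nitrogen proves not to be required, and the much smaller methyl holds the number at the same level. The comparison with chloro gives a 1.4-fold lower number from compound 1 to compound 3 (0.14 log units; within the scatter) and so chloro, anilino and methylamino on this aromatic carbon all lie within the scatter of one another, which widens the earlier single step into a set of three compounds with no separation among them. Nothing available accounts for this lack of separation.

Going by these compounds, whether the level holds for a free amine, a morpholine, a carboxylic acid or a longer alkyl chain on this aromatic carbon remains open. So does the effect of changing the phenyl or the nitrile elsewhere on the shared core.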